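The source may report more compounds than this note shows. Statements on the series, on what has been measured and on what is new or still open speak of the compounds shown alone.

Measured so far:
compound 1, `N#Cc1ccc(NC(=O)c2cc(Cc3ccccc3)ccc2O)cc1`: 1740 nM
compound 2, `N#Cc1ccc(NC(=O)c2ccc[nH]c2=O)cc1`: > 10000 nM

Compound 1 holds the only number shown in a functional assay on HL-60 cells (Homo sapiens) for cytotoxicity, read by luminescence and CellTiter-Glo, with a stated time of 3 days (on this read-out lower numbers stand for stronger inhibition and higher numbers for weaker inhibition), where compound 1 gives 1740 nM. Compound 2 gives only a limit of the assay in this assay, > 10000 nM, which is the limit of > 10000 nM in this assay, at which 1 of the 2 values shown sits, and not a number. Among the measured compounds shown here, no two measured compounds differ in one place, so no measured step is available to set a scale.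

Compound 3, `Cc1ccc(O)c(C(=O)Nc2ccc(C#N)cc2)c1`, is not yet measured in this assay. Against compound 1 the change is hydrogen in place of phenyl on a saturated chain carbon bound to an aromatic carbon. The expectation for compound 3 can rest only on the number for compound 1. The change is expected to run toward weaker inhibition, beyond the scatter, the expected step being a 3.2-fold higher number from compound 1 to compound 3 (0.50 log units; beyond the scatter). Compound 3 is expected to give about 5500 nM in this assay, within 1700 nM to 15000 nM, with a fair chance that only a limit is returned.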

Compound 3, half-maximal inhibitory concentration: 3920 nM
Compound 3: the middle estimate sits 1.4-fold (0.15 log units) above what was measured, and the stated range covers the measured number.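

In this assay, among the compounds shown here, the change from benzyl to methyl gives the first measured step at this position, a 2.3-fold higher number from compound 1 to compound 3 (0.35 log units; beyond the scatter), a modest loss that lies beyond the scatter. The phenyl is not needed for a measurable number here, since compound 3 without it still gives 3920 nM. Compound 2, which differs from compound 1 and compound 3 in more than one place, has a limit and not a number: the limit of > 10000 nM in this assay, at which 1 of the 3 values shown sits.

A single step sets no trend, so the compounds shown leave open how the number moves with other groups in place of the phenyl on this saturated chain carbon, such as an amine, a carboxylic acid or a longer chain. They also give no measured property that would explain the loss on removing the phenyl.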